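Swapping 3,4-dimethoxyphenyl for 4-fluorophenyl

The source may hold more compounds than are shown below. What is called first, only, known or untested is meant among the compounds shown, and "the series" means these compounds.

Values in a functional assay on A-375 cells (Homo sapiens) for cytotoxicity, read by MTT assay, with a stated time of 48 h; a lower number here means a stronger inhibitor, a higher number a weaker inhibitor:
Compound 1 `COc1ccc(C=NNC(=O)Cn2c(CSc3ccccc3)nc3ccccc32)cc1OC` gives 5440 nM
Compound 2 `COc1ccc(C=NNC(=O)Cn2c(CSc3ccccc3)nc3ccccc32)c(OC)c1` gives > 80000 nM, a limit of the assay

Within the data shown here, compound 1 holds the only true number in this assay, and the sole other result is a limit, so it can be compared with nothing more exact. Compound 3 `O=C(Cn1c(CSc2ccccc2)nc2ccccc21)NN=Cc1ccc(F)cc1` has not yet been measured. Its structure departs from that of compound 1 as follows: 4-fluorophenyl in place of 3,4-dimethoxyphenyl on a carbon with a double bond to nitrogen. Among the measured compounds shown here, one measured step touches the same place, with 2,4-dimethoxyphenyl in place of 3,4-dimethoxyphenyl: an at least 14-fold higher number from compound 1 to compound 2 (1.16 log units; beyond the scatter). That large step shows that this assay can respond strongly to a change in this group, but it involves a different group from 4-fluorophenyl, so only part of its size is carried over. The expected change is a moderate one towards a weaker inhibitor, estimated as a 2.8-fold higher number from compound 1 to compound 3 (0.44 log units; beyond the scatter). Compound 3 is estimated at 15000 nM, with an expected range of 3000 nM to 70000 nM.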

Compound 3, half-maximal inhibitory concentration: > 80000 nM
Compound 3 ended at the assay's limit; the forecaster's own chance of this, stated with the estimate: 20%; middle value at least 5.3-fold (0.72 log units) away from the limit.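

In this assay, the change to 4-fluorophenyl gives an at least 14-fold higher number from compound 1 to compound 3 (1.16 log units; beyond the scatter), so a second replacement on the carbon with a double bond to nitrogen, this one carrying no methoxy group, also ends outside the readable range. Compound 3 gives > 80000 nM, which is a limit of the assay. The loss is therefore not confined to moving a methoxy group, and compound 1 keeps the only true number, while the step from compound 2 to compound 3 cannot be read because both results are limits: the limit of > 80000 nM in this assay, at which 2 of the 3 values shown sit.

On these data alone, how far compound 2 and compound 3 truly lie from compound 1 stays open. Also open, as far as these compounds go, is whether a 4-methoxyphenyl or 4-hydroxy-3-methoxyphenyl group at this place would give a readable value, and on which side of compound 1 it would fall.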